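Swapping a Benzoyl for a Chlorophenylsulfonyl Group

This account rests on a few compounds, and the source may have more. Where it says the series, first, only, none or still open, it means among the compounds named here.

Compound 1 `O=C(Nc1cccc(/C=C/C(=O)c2nc3ccccc3[nH]2)c1)c1ccccc1` holds the second highest of the three numbers in a functional assay on MCF7 cells (Homo sapiens) for antiproliferative activity, read by MTT assay, with a stated time of 48 h (on this read-out higher numbers stand for weaker inhibition and lower numbers for stronger inhibition), at 11200 nM. Compound 2 `Cc1ccc(C(=O)Nc2cccc(/C=C/C(=O)c3nc4ccccc4[nH]3)c2)cc1` gives 9690 nM, and compound 3 `COc1ccc(C(=O)Nc2cccc(/C=C/C(=O)c3nc4ccccc4[nH]3)c2)cc1` gives 20100 nM. The measured steps are small: a 1.2-fold lower number from compound 1 to compound 2 (0.06 log units; within the scatter), a 1.8-fold higher number from compound 1 to compound 3 (0.25 log units; within the scatter), while a 2.1-fold higher number from compound 2 to compound 3 (0.32 log units; beyond the scatter). Compound 4 `O=C(/C=C/c1cccc(NS(=O)(=O)c2ccc(Cl)cc2)c1)c1nc2ccccc2[nH]1` differs from compound 1 by a larger change: (4-chlorophenyl)sulfonyl in place of benzoyl on a nitrogen on an aromatic ring. Among the measured compounds shown here, none of the measured steps touches this kind of change; all three only vary a group on the benzoyl that now leaves, and they hardly move the numbers. The expected step is therefore a 1.1-fold lower number from compound 1 to compound 4 (0.05 log units; within the scatter), with no shift beyond the scatter anticipated. Compound 4 is estimated at 10000 nM, within a range from 3000 nM to 35000 nM.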

Compound 4, half-maximal inhibitory concentration: 3820 nM
Beside the measured number, compound 4's estimate is 2.6-fold (0.42 log units) above it, and the stated range covers the measured number.
By their numbers in this assay, from the lowest: compound 4; then compounds 2, 1 and 3 (each within the scatter of the next, the first and the last beyond it).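

In this assay the nitrogen on the aromatic ring proves a more responsive place than the benzoyl ring alone suggested, with a 2.9-fold lower number from compound 1 to compound 4 (0.47 log units; beyond the scatter), a 2.5-fold lower number from compound 2 to compound 4 (0.40 log units; beyond the scatter) and a 5.3-fold lower number from compound 3 to compound 4 (0.72 log units; beyond the scatter). All three steps lie beyond the scatter, so compound 4 gives the strongest inhibition of the four. No measurement here explains this shift.

The change replaces the carbonyl with a sulfonyl and adds a chlorine in one move, so the compounds shown cannot separate the two. From the compounds shown here alone, how a 4-chlorobenzoyl or a plain phenylsulfonyl group on this nitrogen would score remains open.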